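The source may hold more compounds than are shown below. What is called first, only, known or untested is meant among the compounds shown, and "the series" means these compounds.

Working notes on a small hemolysis series. Going by the values given here, compound 1 `[O-][n+]1onc2ccc(COc3ccccc3/C=N\NC(=S)Nc3ccccc3)cc21` is the first member; in an ADME assay on cells (Erythrocyte, Homo sapiens), read by spectrophotometry and hemolysis, with a stated time of 24 h (on this read-out lower numbers stand for stronger inhibition and higher numbers for weaker inhibition), compound 1 reaches only a limit, > 200 uM. Compound 2 `NC(=O)N/N=C\c1ccccc1OCc1ccc2no[n+]([O-])c2c1` differs from compound 1 by a group of 3 heavy atoms (1 carbon, 1 nitrogen, 1 oxygen; no ring) in place of a group of 9 heavy atoms (7 carbon, 1 nitrogen, 1 sulfur; one six-membered aromatic ring of carbon only), on an amine nitrogen. In this assay compound 2 also gives only a limit, > 100 uM. The step that the two limits leave unreadable from compound 1 to compound 2 cannot be sized because the limit of > 200 uM in this assay, at which 1 of the 3 values shown sits, and the limit of > 100 uM in this assay, at which 1 of the 3 values shown sits, both stand on the weak side of the read-out. Compound 3 `CC1(C)[N+]([O-])=c2ccc(COc3ccc(/C=N/NC(=S)Nc4ccccc4)cc3)cc2=[N+]1[O-]` sits on another core; how the two cores differ is not broken down here. In this assay compound 3 gives only a limit, < 50 uM, which is what the limit of < 50 uM in this assay, at which 1 of the 3 values shown sits, records. Compound 4 `CC1(C)[N+]([O-])=c2ccc(COc3ccc(/C=N/NC(N)=O)cc3)cc2=[N+]1[O-]` is still to be measured in this assay; it differs from compound 3 by a group of 3 heavy atoms (1 carbon, 1 nitrogen, 1 oxygen; no ring) in place of a group of 9 heavy atoms (7 carbon, 1 nitrogen, 1 sulfur; one six-membered aromatic ring of carbon only), on an amine nitrogen, the same change as that made between compound 1 and compound 2. Since the earlier step is unreadable, the expected step of an at least 2.0-fold higher number from compound 3 to compound 4 (0.30 log units; that floor lies within the scatter) rests on no measured number and is taken as roughly neutral. Compound 4 is therefore expected to give about 100 uM in this assay, plausibly anywhere between 30 uM and 300 uM.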

Compound 4, concentration for 50% inhibition: > 200 uM
Compound 4 ended at the assay's limit; the forecaster's own chance of this, stated with the estimate: 70%; at least 2.0-fold (0.30 log units) between middle value and limit.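

On the core of compound 3, carbamoyl in place of the group of 9 heavy atoms with its six-membered aromatic ring of carbon only, on an amine nitrogen, gives an at least 4.0-fold higher number from compound 3 to compound 4 (0.60 log units; beyond the scatter) in this assay. On these data alone, compound 3 stands at < 50 uM, which is a limit of the assay and not a number, so this step is only a floor and its true size stays unknown. The same change on the core of compound 1 cannot be read, with both of its ends at limits on the weak side of the read-out, so the series gives a readable step on one core only and does not show that the change carries over to another core.

The compounds shown leave open how far the true values of compound 3 and compound 4 lie from their limits. They also leave open whether an amine, a carboxylic acid or a longer chain on that amine nitrogen would behave as carbamoyl does in this assay.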